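Swapping the Ring-Nitrogen Substituent Toward an Amide

The source may report more compounds than this note shows. Statements on the series, on what has been measured and on what is new or still open speak of the compounds shown alone.

Measured so far in an assay on membranes from Cortex for displacement of a labelled ligand from Sigma non-opioid intracellular receptor 1 (Cavia porcellus), read by scintillation counting, with a stated time of 120 min; on this read-out lower numbers stand for stronger inhibition and higher numbers for weaker inhibition: compound 1 `Fc1ccc(C(SCCNC2CCN(Cc3ccc(Cl)cc3)CC2)c2ccc(F)cc2)cc1` gives 45.5 nM; compound 2 `OC(Cc1ccccc1)CN1CCC(NCCSC(c2ccc(F)cc2)c2ccc(F)cc2)CC1` gives 309 nM.

Compound 2 stands highest of the two numbers shown, the step from compound 1 being a 6.8-fold higher number from compound 1 to compound 2 (0.83 log units; beyond the scatter). Compound 3 `O=C(c1ccc(F)cc1)N1CCC(NCCSC(c2ccc(F)cc2)c2ccc(F)cc2)CC1` changes the same place again: (4-fluorophenyl)carbonyl in place of 2-hydroxy-3-phenylpropyl on an amine nitrogen in a ring. Among the compounds with values here, only that single measured step bears on this position, and it was modest; it shows the group here matters but gives no direct guide for an amide. Compound 3 is therefore expected to show a 1.9-fold higher number from compound 2 to compound 3 (0.29 log units; within the scatter), a modest rise with wide uncertainty in direction. The estimate for compound 3 is 600 nM, within 150 nM to 2500 nM.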

Compound 3, inhibition constant: 32.1 nM
Compound 3: the middle estimate sits 19-fold (1.27 log units) above what was measured; the measured number lies below the stated range.
By their numbers in this assay, from the lowest: compounds 3 and 1 (each within the scatter of the next); then compound 2.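

In this assay, a group joined through a carbonyl on this ring nitrogen is compatible with low numbers: (4-fluorophenyl)carbonyl in place of 2-hydroxy-3-phenylpropyl gives a 9.6-fold lower number from compound 2 to compound 3 (0.98 log units; beyond the scatter). In place of 4-chlorobenzyl, the same group gives a 1.4-fold lower number from compound 1 to compound 3 (0.15 log units; within the scatter), so compound 1 and compound 3 cannot be told apart here despite their different links to the nitrogen. Nothing available explains this result.

From the compounds shown here alone, whether the carbonyl or the fluorine on its ring counts remains open. A plain benzoyl or an acetyl group on the same nitrogen would bear on that question.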